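A few compounds are considered here, and "the series" means these few. Any claim that something is new, unique, unknown or untested is made for them only; others in the source may bear on it.

Three close analogues have been tested in an ADME assay on MT4 cells (Homo sapiens) for cytotoxicity, read by MTT assay, with a stated time of 4 days; a lower number here means that less compound is tolerated, a higher number that more compound is tolerated. Compound 1 `CNC(=O)Nc1c(C)c(C(OC(C)(C)C)C(=O)O)c(-c2ccc(C)c(C)c2)c(C)c1-c1ccc(C)c(C)c1` gives 20000 nM; compound 2 `Cc1ccc(-c2c(C)c(-c3ccc(C)c(C)c3)c(C(OC(C)(C)C)C(=O)O)c(C)c2NS(=O)(=O)C2CC2)cc1C` gives 11000 nM; compound 3 `Cc1ccc(-c2c(C)c(-c3ccc(C)c(C)c3)c(C(OC(C)(C)C)C(=O)O)c(C)c2N)cc1C` gives 12000 nM. Compound 3 stands with the other two so that every gap is within the scatter: a 1.8-fold lower number from compound 1 to compound 2 (0.26 log units; within the scatter), a 1.7-fold lower number from compound 1 to compound 3 (0.22 log units; within the scatter) and a 1.1-fold higher number from compound 2 to compound 3 (0.04 log units; within the scatter). Compound 4 `Cc1ccc(-c2c(C)c(-c3ccc(C)c(C)c3)c(C(OC(C)(C)C)C(=O)O)c(C)c2NS(=O)(=O)c2ccccc2)cc1C` differs from compound 3 by phenylsulfonyl in place of hydrogen on a nitrogen on an aromatic ring. Among the compounds with values here, the nearest precedent is the reverse removal of another sulfonyl group, a 1.1-fold higher number from compound 2 to compound 3 (0.04 log units; within the scatter), which stayed within the scatter, and the removal of a methylcarbamoyl group, a 1.7-fold lower number from compound 1 to compound 3 (0.22 log units; within the scatter), stayed there too. In this assay a step of no change at the digits printed from compound 3 to compound 4 (within the scatter) is therefore expected, none beyond the scatter. Compound 4 is expected to give 12000 nM, within a range from 6000 nM to 25000 nM.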

Compound 4, half-maximal cytotoxic concentration: 11000 nM
Estimate against measurement, compound 4: 1.1-fold (0.04 log units) above; the measured number falls inside the stated range.
By their numbers in this assay, from the lowest: compounds 2, 4, 3 and 1 (each within the scatter of the next).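

At this nitrogen on an aromatic ring, a phenylsulfonyl group now proves no different from hydrogen, with a 1.1-fold lower number from compound 3 to compound 4 (0.04 log units; within the scatter) in this assay. Phenyl in place of cyclopropyl on the sulfonyl sulfur gives no change at the digits printed from compound 2 to compound 4 (within the scatter) as its result, and phenylsulfonyl in place of methylcarbamoyl gives a 1.8-fold lower number from compound 1 to compound 4 (0.26 log units; within the scatter) as its result, both also within the scatter. Across these four compounds, no group on this nitrogen separates one number from another beyond the scatter, and no measurement at hand explains this. The compounds shown leave open whether a carboxylic acid or a dimethylamino group on the sulfonyl-bearing nitrogen, or a longer alkyl chain on the sulfonyl sulfur, would also stay within the scatter.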